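Aryl groups on the fused core: the step to compound 4

This account rests on a few compounds, and the source may have more. Where it says the series, first, only, none or still open, it means among the compounds named here.

Compound 1 `COc1n[nH]c2ncc(C#Cc3c(F)ccc(NS(=O)(=O)c4cccnc4)c3F)cc12` gives 1280 nM in a functional assay on HCT-116 cells (Homo sapiens) for antiproliferative activity, read by MTT assay, with a stated time of 68 h; on this read-out higher numbers stand for weaker inhibition and lower numbers for stronger inhibition.
Compound 2 `O=S(=O)(Nc1ccc(F)c(C#Cc2cnc3[nH]nc(-c4ccccc4)c3c2)c1F)c1cccnc1` gives > 10000 nM in this assay, which is a limit.
Compound 3 `O=S(=O)(Nc1ccc(F)c(C#Cc2cnc3[nH]nc(-c4ccncc4)c3c2)c1F)c1cccnc1` gives > 10000 nM in this assay, which is a limit.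

Compound 3 thus stands at the limit, where two of the three values sit (the limit of > 10000 nM in this assay, at which 2 of the 3 values shown sit). The step to compound 4 `O=S(=O)(Nc1ccc(F)c(C#Cc2cnc3[nH]nc(-c4ccccc4Cl)c3c2)c1F)c1cccnc1` is 2-chlorophenyl in place of pyridin-4-yl on an aromatic carbon. Within the data shown here, the steps that bear on it are an at least 7.8-fold higher number from compound 1 to compound 2 (0.89 log units; beyond the scatter) and an at least 7.8-fold higher number from compound 1 to compound 3 (0.89 log units; beyond the scatter), both reaching the limit, while a step that the two limits leave unreadable from compound 2 to compound 3. Since phenyl and pyridin-4-yl both sit at the limit, the 2-chlorophenyl of compound 4 is expected to stay there, with a step that the limit leaves unreadable from compound 3 to compound 4. The estimate for compound 4 is therefore 12000 nM, between 3000 nM and 40000 nM.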

Compound 4, half-maximal inhibitory concentration: > 10000 nM
Compound 4 was reported as a limit (the forecaster's own chance of this, stated with the estimate: 70%); the middle value is on the limit's open side.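

In this assay compound 4 gives > 10000 nM, which is a limit, so a 2-chlorophenyl group on this carbon gives no measurable value, as phenyl and pyridin-4-yl did not. Replacing methoxy with 2-chlorophenyl gives an at least 7.8-fold higher number from compound 1 to compound 4 (0.89 log units; beyond the scatter). The steps among compound 2, compound 3 and compound 4 cannot be read, so neither the added chloro nor the loss of the ring nitrogen shows a size, and the result adds one more compound to the shared limit: the limit of > 10000 nM in this assay, at which 3 of the 4 values shown sit.

As far as these compounds go, how far these compounds lie beyond the limit stays open. Also open, from the compounds shown here alone, is whether an amine or an ethoxy group on this carbon would match compound 1 at 1280 nM.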